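Methoxy in Place of Hydrogen: From Compound 2 to Compound 3

The source may hold more compounds than are shown below. What is called first, only, known or untested is meant among the compounds shown, and "the series" means these compounds.

Of the compounds shown here, two have so far been measured in a functional assay on the whole organism (strain albino) for inhibition, with Rattus norvegicus as the target, read by paw edema, with a stated time of 5 h, at a dose of 0.28 mmol/kg by the oral route; on this read-out higher numbers stand for more inhibition at the one dose given (going by the name of the read-out) and lower numbers for less inhibition. Compound 1 `COc1ccc(-c2nnc(SC/C(=N/O)c3ccccc3)n2-c2ccccc2)cc1` gives 73% in this assay. Compound 2 `O=C(CSc1nnc(-c2ccccc2)n1-c1ccccc1)c1ccccc1` gives 63% in this assay, the lowest of the two numbers, though its gap to compound 1 lies within the scatter, so the two cannot be set in order. Among the compounds with values here, no pair of measured compounds differs in only one place, so no single step has been measured. Compound 3 `COc1ccc(-c2nnc(SCC(=O)c3ccccc3)n2-c2ccccc2)cc1` has not yet been measured; it differs from compound 2 by methoxy in place of hydrogen on an aromatic carbon. Compound 1 carries the same methoxy and gives 73%, while compound 2 gives 63%, a gap within the scatter, so no large effect of the exchange is apparent. The step is expected to be small, a number 5 percentage points higher from compound 2 to compound 3 (within the scatter), none beyond the scatter in either direction. Compound 3 is therefore estimated at 68% in this assay, within a range from 55% to 80%.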

Compound 3, a percentage reported as inhibition, in the whole organism at one dose (the size of the read-out at that dose, not a potency): 61%
Compound 3: the middle estimate sits 7 percentage points above what was measured; the range from low to high includes it.
By their numbers in this assay, from the lowest: compounds 3, 2 and 1 (each within the scatter of the next, the first and the last beyond it).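

In this assay, phenyl to 4-methoxyphenyl is now a measured single change (a number 2 percentage points lower from compound 2 to compound 3 (within the scatter)), so methoxy in place of hydrogen at this place, para to a large group, has no effect that can be told from the scatter. Within the data shown here, compound 3 also gives the first step that lies beyond the scatter, a modest one, with a group of 8 heavy atoms in place of a group of 9 heavy atoms on the saturated chain carbon bound to a sulfur (a number 12 percentage points lower from compound 1 to compound 3 (beyond the scatter)). Nothing at hand explains either step.

Going by these compounds, whether an amine or a carboxylic acid at this place would move the number beyond the scatter stays open. On these data alone, it is also open whether the step on the chain carbon would hold with phenyl in place of 4-methoxyphenyl.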